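A Hydroxycyclohexyl Amine Replaces Isopropyl on a Shared Core

A few compounds are considered here, and "the series" means these few. Any claim that something is new, unique, unknown or untested is made for them only; others in the source may bear on it.

Three measured compounds share one core and differ only at the aromatic amine and its neighbouring halogen. Compound 1 `CC(C)Nc1ccc(-c2ccn3c(CC4CC4)nnc3c2C(F)(F)F)cc1F` gives 2.2 nM in an assay on cells for binding affinity to metabotropic glutamate receptor 2 (Homo sapiens), read by scintillation proximity assay; a lower number here means tighter binding, a higher number weaker binding. Compound 2 `CC(C)Nc1ccc(-c2ccn3c(CC4CC4)nnc3c2C(F)(F)F)cc1Cl` gives 3.4 nM, and compound 3 `COc1ccc(CNc2ccc(-c3ccn4c(CC5CC5)nnc4c3C(F)(F)F)cc2)cn1` gives 2 nM. The step of a 1.5-fold higher number from compound 1 to compound 2 (0.19 log units; within the scatter) is within the scatter, and compound 2 holds the highest of the three numbers, with compound 1 and compound 3 both within the scatter of it. Compound 4 `O[C@]1(C2CC2)CC[C@H](Nc2ccc(-c3ccn4c(CC5CC5)nnc4c3C(F)(F)F)cc2Cl)CC1` differs from compound 2 by 4-cyclopropyl-4-hydroxycyclohexyl in place of isopropyl on a nitrogen on an aromatic ring. Within the data shown here, no measured step touches this nitrogen; the single step measured concerns the halogen and lies within the scatter. Among the measured compounds shown here, the values of compound 2 and compound 3 show only that a larger group on that nitrogen coexists with a similar number. Compound 4 is therefore expected to show no step beyond the scatter, a 1.0-fold higher number from compound 2 to compound 4 (0.01 log units; within the scatter). Compound 4 is estimated at 3.5 nM, within 1.2 nM to 11 nM.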

Compound 4, dissociation constant: 1.5 nM
Beside the measured number, compound 4's estimate is 2.3-fold (0.37 log units) above it; the range from low to high includes it.
By their numbers in this assay, from the lowest: compounds 4, 3, 1 and 2 (each within the scatter of the next, the first and the last beyond it).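

In this assay, the nitrogen on an aromatic ring now has a measured step of its own, a 2.3-fold lower number from compound 2 to compound 4 (0.36 log units; beyond the scatter), for 4-cyclopropyl-4-hydroxycyclohexyl in place of isopropyl. The earlier compounds shown here gave only a halogen step within the scatter, whereas this one shows that the position takes a far bulkier group with two rings and a hydroxyl without losing binding. Nothing available explains the step.

The compounds shown leave open whether a plain cyclohexyl or a cyclopropyl without the hydroxyl would give the same step. They also leave open whether it would hold with fluoro in place of chloro.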